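This account rests on a few compounds, and the source may have more. Where it says the series, first, only, none or still open, it means among the compounds named here.

Compound 1 `CSc1ccccc1C#Cc1ccccc1C#CCCCCO` gives 14700 nM.
Compound 2 `OCCCCC#Cc1ccccc1C#Cc1ccccc1C(F)(F)F` gives 2300 nM.
Compound 3 `COc1cccc(C#Cc2ccccc2C#CCCCCO)c1` gives 10700 nM.

All three numbers come from a functional assay on OVCAR-3 cells (Homo sapiens) for cytotoxicity; on this read-out higher numbers stand for weaker inhibition of growth and lower numbers for stronger inhibition of growth. Among them compound 3 gives the second highest number; compound 1 sits nearest to it, within the scatter, while compound 2 lies furthest away, beyond the scatter. Compound 4 `OCCCCC#Cc1ccccc1C#Cc1cccc(C(F)(F)F)c1` differs from compound 3 by trifluoromethyl in place of methoxy on an aromatic carbon. Among the compounds with values here, one measured step bears on this change: a 6.4-fold lower number from compound 1 to compound 2 (0.81 log units; beyond the scatter), where trifluoromethyl also entered, though there it replaced methylsulfanyl rather than methoxy. A drop in the number is therefore expected in this assay, somewhat smaller than that one, about a 2.7-fold lower number from compound 3 to compound 4 (0.43 log units; beyond the scatter). Compound 4 is estimated at 4000 nM, with a range from 1500 nM to 12000 nM.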

Compound 4, concentration for 50% growth inhibition: 16800 nM
Beside the measured number, compound 4's estimate is 4.2-fold (0.62 log units) below it; the measured number lies above the stated range.
By their numbers in this assay, from the lowest: compound 2; then compounds 3, 1 and 4 (each within the scatter of the next).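

In this assay, placing trifluoromethyl instead of methoxy meta to a large group gives a 1.6-fold higher number from compound 3 to compound 4 (0.20 log units; within the scatter) and leaves the two compounds within the scatter of each other. The clear drop in a 6.4-fold lower number from compound 1 to compound 2 (0.81 log units; beyond the scatter) therefore does not extend to this change, so entry of trifluoromethyl does not lower the number in every setting. Nothing measured here explains this contrast.

Still open, on these data alone, is whether an amine or a carboxylic acid at this position would shift the number beyond the scatter. Also open, as far as these compounds go, is how methoxy would behave at the position that trifluoromethyl holds in compound 2.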